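This account rests on a few compounds, and the source may have more. Where it says the series, first, only, none or still open, it means among the compounds named here.

Compound 3 `O=C(O)COc1ccc(NCc2cccc(-c3ccccc3Cl)c2)cc1F` gives 19.3 nM in a functional assay on CHO cells for agonist activity at Free fatty acid receptor 1 (Homo sapiens), read by FLIPR and calcium flux (on this read-out higher numbers stand for an effect only at larger amounts of compound and lower numbers for an effect already at smaller amounts), the lowest of the three numbers measured. Compound 1 `CCOc1cc(C)c(-c2cccc(CNc3ccc(OCC(=O)O)c(F)c3)c2)c(C)c1` gives 24.2 nM in this assay, within the scatter of compound 3, whereas compound 2 `CCOc1cc(C)c(-c2cccc(CNc3ccc(OCC(=O)O)cc3)c2)c(C)c1` gives 197 nM, beyond it. Within the data shown here, the only measured step, an 8.1-fold higher number from compound 1 to compound 2 (0.91 log units; beyond the scatter), concerns hydrogen for fluoro on the aromatic carbon of the amine-bearing ring and does not touch the change considered here.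

Compound 4 `N#Cc1ccccc1-c1cccc(CNc2ccc(OCC(=O)O)c(F)c2)c1` differs from compound 3 by cyano in place of chloro on an aromatic carbon, ortho to a large group. Among the measured compounds shown here, no measured step bears on this exchange, so nothing beyond the scatter is expected. Compound 4 is estimated at 30 nM, range 10 nM to 90 nM, an expected step of a 1.6-fold higher number from compound 3 to compound 4 (0.19 log units; within the scatter).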

Compound 4, half-maximal effective concentration: 729 nM
Compound 4: the middle estimate sits 24-fold (1.39 log units) below what was measured; the whole stated range lies below it.
By their numbers in this assay, from the lowest: compounds 3 and 1 (each within the scatter of the next); then compound 2; then compound 4.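

At the aromatic carbon ortho to a large group, chloro and cyano are not interchangeable in this assay: going from 2-chlorophenyl to 2-cyanophenyl gives a 38-fold higher number from compound 3 to compound 4 (1.58 log units; beyond the scatter). Among these compounds, the earlier step concerned only the fluoro on the amine-bearing ring, so this is the first reading of a change at this position. Nothing shown accounts for the size of this step.

As far as these compounds go, it remains open whether a methoxy or trifluoromethyl group here would track chloro or cyano. Also open, from the compounds shown here alone, is whether this step persists with hydrogen in place of the fluoro.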